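The source may hold more compounds than are shown below. What is called first, only, known or untested is meant among the compounds shown, and "the series" means these compounds.

Measured so far in a functional assay on BV-2 cells (Mus musculus) for inhibition, read by ELISA, with a stated time of 16 h; on this read-out higher numbers stand for weaker inhibition and lower numbers for stronger inhibition:
- compound 1 `Cc1cc(C)c(N2CCN(c3ncccn3)CC2)nn1`: > 100000 nM
- compound 2 `Cc1cc(-c2ccc(F)cc2)nnc1N1CCN(c2ncccn2)CC1`: 76300 nM
- compound 3 `Cc1ccc(-c2cc(C)c(N3CCN(c4ncccn4)CC3)nn2)cc1`: 17200 nM

Compound 1 gives only the limit of > 100000 nM in this assay, at which 1 of the 3 values shown sits, rather than a number. Of the two numbers, compound 3 stands lowest; its nearest neighbour is compound 2, with a 4.4-fold lower number from compound 2 to compound 3 (0.65 log units; beyond the scatter) separating them. Against compound 1 the steps are an at least 1.3-fold lower number from compound 1 to compound 2 (0.11 log units; that floor lies within the scatter) and an at least 5.8-fold lower number from compound 1 to compound 3 (0.76 log units; beyond the scatter), so the aryl group on the shared core lowers the number, and the methyl-bearing aryl does so more than the fluoro-bearing one.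

Compound 4 `Cc1cc(-c2ccncc2)nnc1N1CCN(c2ncccn2)CC1` is not yet measured. The change from compound 3 is pyridin-4-yl in place of 4-methylphenyl on an aromatic carbon. Within the data shown here, no measured step swaps an aryl ring for a heteroaryl ring; the closest guide is the step from compound 2 to compound 3, which shows that losing the methyl on the aryl ring raises the number. Removing the 4-methylphenyl in favour of pyridin-4-yl is therefore expected to raise the number, with a 2.9-fold higher number from compound 3 to compound 4 (0.46 log units; beyond the scatter) as the estimated step. Compound 4 is expected at 50000 nM, in the range 15000 nM to 200000 nM.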

Compound 4, half-maximal inhibitory concentration: > 100000 nM
Compound 4: only a limit was reported; the forecaster's own chance of this, stated with the estimate: 25%; middle value at least 2.0-fold (0.30 log units) from the limit.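

In this assay, compound 4 is the only compound shown with a hetero atom in the ring on this aromatic carbon, next to the ring nitrogen, and pyridin-4-yl in place of 4-methylphenyl gives an at least 5.8-fold higher number from compound 3 to compound 4 (0.76 log units; beyond the scatter). Compound 4 gives only a limit, > 100000 nM, and not a number. Against 4-fluorophenyl the reading is an at least 1.3-fold higher number from compound 2 to compound 4 (0.11 log units; that floor lies within the scatter), so this change does not separate pyridin-4-yl from 4-fluorophenyl, and only the 4-methylphenyl ring of compound 3 stands clear of pyridin-4-yl.

The step from compound 1 to compound 4 cannot be read because both compounds sit at the limit: the limit of > 100000 nM in this assay, at which 2 of the 4 values shown sit. Open, going by these compounds, is whether an amine, a carboxylic acid or a longer chain in place of the methyl on the phenyl ring of compound 3 would move the number in either direction.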